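This account rests on a few compounds, and the source may have more. Where it says the series, first, only, none or still open, it means among the compounds named here.

Compound 1 `Cc1nc(C)c(C(=O)Oc2ccc(/C=C/C(=O)O)cc2O)nc1C`: 285%
Compound 2 `CCOC(=O)/C=C/c1ccc(OC(=O)c2nc(C)c(C)nc2C)cc1`: 62.6%

In a functional assay on EA.hy 926 cells (Homo sapiens) for cytotoxicity, read by MTT assay, with stated times of 24 h and 12 h, tested at 50 uM (a lower number here means a weaker effect, a higher number a stronger effect of the compound at the concentration tested), compound 2 gives 62.6%, the lower of the two numbers; compound 1 gives 285%, a difference well beyond the usual scatter. Compound 3 `Cc1nc(C)c(C(=O)Oc2ccc(/C=C/C(=O)O)cc2)nc1C` has not been measured. It differs from compound 2 in one place: hydrogen in place of ethyl on an oxygen next to a carbonyl group. Going by the values given here, no measured pair shows this change on its own, so its size cannot be read from the data. An upward step is expected because compound 1 also carries the carboxy group and gives 285%. The step of a number 97.4 percentage points higher from compound 2 to compound 3 (beyond the scatter) is expected to be large. Compound 3 is estimated at 160%, within 70% to 290%.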

Compound 3, a percentage reported as activity, at one concentration (the size of the read-out at that concentration, not a potency): 74.1%
Compound 3: middle estimate off by 85.9 percentage points, on the high side; measured number inside the range.
By their numbers in this assay, from the lowest: compound 2; then compound 3; then compound 1.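

In this assay, the change from ethoxycarbonyl to carboxy gives a number 11.5 percentage points higher from compound 2 to compound 3 (beyond the scatter), a modest step on its own. Putting hydrogen in place of hydroxy on an aromatic carbon gives a number 210.9 percentage points lower from compound 1 to compound 3 (beyond the scatter), a large step, so among these compounds the high number goes with the hydroxy and not with the carboxy group alone. Nothing shown here explains either step.

As far as these compounds go, it remains open whether the hydroxy goes with so high a number when the ethyl ester is present. Also open, from the compounds shown here alone, is how a methoxy group or an amine on that aromatic carbon, or a longer chain in place of ethyl, would read.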